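A few compounds are considered here, and "the series" means these few. Any claim that something is new, unique, unknown or untested is made for them only; others in the source may bear on it.

Compound 1 `O=C(CN(c1nc(Cl)nc2[nH]cnc12)C1CC1)N[C@@H](CC(=O)OCc1ccccc1)C(=O)OCc1ccccc1` was tested in a functional assay on the whole organism (Tail, strain ICR) with Mus musculus as the target, in the tail flick test, with a stated time of 90 min, at a dose of 25 umol/kg by the oral route (a lower number here means a weaker effect, a higher number a stronger effect of the compound at the dose given), where compound 1 gives 15.6%. A second compound, compound 2 `C[C@H](NC(=O)CN(c1nc(Cl)nc2[nH]cnc12)C1CC1)C(=O)O`, gives 43.5% in this assay; compound 1 stands lowest of the two numbers, and the gap to compound 2 lies beyond the usual scatter of this kind of measurement. Compound 1 and compound 2 differ in more than one place, so their two values alone cannot be tied to a single change.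

Compound 3 `NC(=O)CC[C@H](NC(=O)CN(c1nc(Cl)nc2[nH]cnc12)C1CC1)C(=O)OCc1ccccc1` has not yet been measured. It arises from compound 1 by one change: carbamoylmethyl in place of benzyloxycarbonyl on a saturated chain carbon, two bonds along the chain from an amide-type nitrogen and a carbonyl carbon. For the measured compounds named here, no measured pair with exactly this change is known, so the expectation rests on the two values shown. The step from compound 1 to compound 3 in this assay is expected to be a modest rise, a number 10.4 percentage points higher from compound 1 to compound 3 (beyond the scatter). Compound 3 is estimated to give 26% in this assay, within a range from 10% to 45%.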

Compound 3, a percentage reported as activity, at one dose (the size of the read-out at that dose, not a potency): 42.8%
For compound 3 the middle estimate is 16.8 percentage points below the measured one; the range from low to high includes it.
By their numbers in this assay, from the lowest: compound 1; then compounds 3 and 2 (each within the scatter of the next).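

In this assay, putting carbamoylmethyl in place of benzyloxycarbonyl on a saturated chain carbon, two bonds along the chain from an amide-type nitrogen and a carbonyl carbon, gives a number 27.2 percentage points higher from compound 1 to compound 3 (beyond the scatter) at the dose tested. For the compounds shown here, this is the first single change that can be read at this place, and it shows that the group there matters for the read-out: the effect does not depend on the six-membered aromatic ring of benzyloxycarbonyl and is in fact greater without it. Nothing measured here accounts for this step.

From the compounds shown here alone, it remains open whether a carboxylic acid, an amine or a longer chain at this place would match carbamoylmethyl. Going by these compounds, the role of the benzyloxycarbonyl group that compound 3 still carries on its other side also remains untested by a single change.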